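The source may report more compounds than this note shows. Statements on the series, on what has been measured and on what is new or still open speak of the compounds shown alone.

Compound 1 `OC[C@@H]1C[C@H](Cn2cnc3c(NC4CCC4)ncnc32)c2c(-c3ccccc3)nnc(-c3ccccc3)c21` gives 90800 nM in an ADME assay on L1210/0 cells (Mus musculus) for cytotoxicity, with a stated time of 48 h; a lower number here means a stronger inhibitor, a higher number a weaker inhibitor. Compound 3 `CC(=O)OCCOCn1cnc2c(Cl)ncnc21` gives 163000 nM in this assay. Compound 2 `O=c1[nH]c(=O)n([C@H]2C[C@H](O)[C@@H](CO)O2)cc1CO` gives 9180 nM in this assay, the lowest of the three numbers; its gap to compound 1 and its larger gap to compound 3 both lie beyond the scatter, so compound 2 is the strongest inhibitor of the measured set.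

Compound 4 `O=c1[nH]c(=O)n([C@H]2C[C@H](O)[C@@H](CO)O2)cc1C#Cc1ccccc1` is not yet measured. It differs from compound 2 in one place: 2-phenylethynyl in place of hydroxymethyl on an aromatic carbon. Within the data shown here, no step between measured compounds matches this change, so the size of the move is uncertain. A move to a lower number in this assay is expected, moderate in size, and expected to reach beyond the scatter, as a 3.1-fold lower number from compound 2 to compound 4 (0.49 log units; beyond the scatter). Compound 4 is therefore estimated at 3000 nM, within a range from 500 nM to 20000 nM.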

Compound 4, half-maximal inhibitory concentration: > 200000 nM
Compound 4 was reported as a limit (the forecaster's own chance of this, stated with the estimate: 5%); middle value at least 66-fold (1.82 log units) away from the limit.
By their numbers in this assay, from the lowest: compound 2; then compounds 1 and 3 (each within the scatter of the next). At a limit, above all of these: compound 4.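

In this assay, 2-phenylethynyl in place of hydroxymethyl on this aromatic carbon gives an at least 21-fold higher number from compound 2 to compound 4 (1.33 log units; beyond the scatter), the first step read at this position, and it runs towards a higher number. Changing this one group is thus enough to move the number strongly. Compound 4 stands at a limit, so the step has no upper end: the limit of > 200000 nM in this assay, at which 1 of the 4 values shown sits.

The compounds shown do not separate the effect of the phenyl ring from that of the triple bond or the removal of hydroxymethyl. As far as these compounds go, how methyl, aminomethyl or a carboxylic acid behaves on this carbon also stays open.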